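The source may report more compounds than this note shows. Statements on the series, on what has been measured and on what is new or still open speak of the compounds shown alone.

Measured so far in an assay on isolated protein for inhibition of Amine oxidase [flavin-containing] B (Homo sapiens), read by fluorescence, with a stated time of 20 min; a higher number here means a weaker inhibitor, a lower number a stronger inhibitor:
compound 1, `COc1cc(O)ccc1C(=O)/C=C/c1ccc(O)c(O)c1`, 1010 nM
compound 2, `COc1cc(O)c(C(=O)/C=C/c2ccccc2O)c(OC)c1`, 2710 nM

Of the two numbers in this assay, compound 1 has the lowest; the nearest is compound 2, whose number is higher by a margin beyond the usual scatter, so compound 1 is the stronger inhibitor of the pair on these figures alone. For the measured compounds named here, no pair of measured compounds differs in a single place, so there is no measured step to lean on.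

Compound 3, `COc1cc(O)ccc1C(=O)/C=C/c1ccc(O)cc1`, is not yet measured. Its change from compound 1 is hydrogen in place of hydroxy on an aromatic carbon, on a six-membered aromatic ring of carbon only, ortho to a hydroxy group and meta to a large group.

With nothing comparable among the measured compounds, the expected step in this assay from compound 1 to compound 3 is estimated as small and, if anything, toward a lower number: a 1.4-fold lower number from compound 1 to compound 3 (0.16 log units; within the scatter). Compound 3 is therefore expected to give about 700 nM in this assay, within a range of 200 nM to 2500 nM, pending the actual measurement.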

Compound 3, half-maximal inhibitory concentration: 380 nM
Compound 3: middle estimate off by 1.8-fold (0.27 log units), on the high side; measured number inside the range.
By their numbers in this assay, from the lowest: compound 3; then compound 1; then compound 2.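

In this assay, for the compounds shown here, hydrogen in place of hydroxy on an aromatic carbon gives a 2.7-fold lower number from compound 1 to compound 3 (0.42 log units; beyond the scatter), the first step that can be read at a single place. The hydroxy group ortho to a hydroxy group and meta to a large group is therefore not required for inhibition on the core of compound 1, and compound 3, which lacks it, is the stronger inhibitor of this pair by a margin beyond the usual scatter. Nothing at hand gives a cause for this step.

Still open, on these data alone, is whether the gain belongs to the absence of the hydroxy group alone or whether other replacements at this place, such as fluorine, chlorine or an amine, would give a similar, lower or higher number. Also open, as far as these compounds go, is whether the hydroxy group that remains on that ring can be replaced in the same way, and whether this step would keep its direction and size on a different core, since it rests on a single pair of compounds.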